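Homologating the Alkyl Chain in a Growth-Inhibition Series

The source may report more compounds than this note shows. Statements on the series, on what has been measured and on what is new or still open speak of the compounds shown alone.

Measured compounds:
Compound 1, `O=C(Nn1c(-c2cccc([N+](=O)[O-])c2)nc2c(-c3ccc(Cl)cc3)n[nH]c2c1=O)c1ccccc1`, 17100 nM
Compound 2, `CCCc1nc2c(-c3ccc(Cl)cc3)n[nH]c2c(=O)n1NC(=O)c1ccccc1`, 29200 nM

Of the compounds shown here, two have been tested in a functional assay on DU-145 cells (Homo sapiens) for inhibition, read by MTT assay, with a stated time of 2 days; a lower number here means a stronger inhibitor of growth, a higher number a weaker inhibitor of growth. Compound 1 gives 17100 nM, and compound 2 gives 29200 nM. For the measured compounds named here, the single measured step is a 1.7-fold higher number from compound 1 to compound 2 (0.23 log units; within the scatter), which means that exchanging the aromatic substituent for a short chain left the number essentially where it was. Compound 2 carries the higher of the two numbers, but the gap to compound 1 is within the scatter, so no order between them can be claimed.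

Compound 3, `CCCCc1nc2c(-c3ccc(Cl)cc3)n[nH]c2c(=O)n1NC(=O)c1ccccc1`, has not yet been tested. It differs from compound 2 by methyl in place of hydrogen on a saturated chain carbon, three bonds along the chain from an aromatic carbon. Going by the values given here, no measured step concerns the lengthening of a chain by one carbon, so the only guidance is that the larger change from compound 1 to compound 2 itself stayed within the scatter. On that basis the expected step in this assay is a 1.0-fold lower number from compound 2 to compound 3 (0.02 log units; within the scatter), that is, no change beyond the scatter in either direction. Compound 3 is therefore estimated at 28000 nM, with a range from 12000 nM to 70000 nM.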

Compound 3, concentration for 50% growth inhibition: 29100 nM
Compound 3: middle estimate off by 1.0-fold (0.02 log units), on the low side, and the stated range covers the measured number.
By their numbers in this assay, from the lowest: compounds 1, 3 and 2 (each within the scatter of the next).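

In this assay, for the compounds shown here, adding methyl in place of hydrogen on a saturated chain carbon, three bonds along the chain from an aromatic carbon, turns propyl into butyl and gives a 1.0-fold lower number from compound 2 to compound 3 (0.00 log units; within the scatter), the first direct reading of chain length at this position. Replacing 3-nitrophenyl with butyl gives a 1.7-fold higher number from compound 1 to compound 3 (0.23 log units; within the scatter), and the earlier change to propyl gave a 1.7-fold higher number from compound 1 to compound 2 (0.23 log units; within the scatter), so both chains now stand within the scatter of the aromatic substituent, and none of the three compounds goes against this. No independent evidence is available to explain why these changes leave the growth-inhibition number within the scatter.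

The three compounds show only one added carbon and one aromatic comparison, so they cannot show whether the same holds for a longer chain such as hexyl. Going by these compounds, it also remains open whether a chain ending in an amine or a carboxylic acid, or a different ring at this position, would move the number beyond the scatter in either direction.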